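Removing an Amide Isopropyl Group on a Shared Core

This account rests on a few compounds, and the source may have more. Where it says the series, first, only, none or still open, it means among the compounds named here.

Four compounds share one core. Compound 1 `CCC1C(=O)N(C)c2cnc(-n3ccc4cc(C(N)=O)ccc43)nc2N1c1ccn(C)n1` is recorded as "not active" (no number reported) in a functional assay on MCF7 cells (Homo sapiens) for antiproliferative activity, read by CCK-8 assay, with a stated time of 72 h; on this read-out higher numbers stand for weaker inhibition of growth and lower numbers for stronger inhibition of growth. Compound 2 `CC[C@@H]1C(=O)N(C)c2cnc(-n3ccc4cc(C(=O)NC(C)C)ccc43)nc2N1C1CCCC1` gives 1670 nM in this assay, and compound 3 `CCC1C(=O)N(C)c2cnc(-n3ccc4cc(C(=O)NC(C)C)ccc43)nc2N1c1ccn(C)n1` gives 8420 nM. Compound 2 shows the lower of the two numbers, and its gap to compound 3 lies beyond the usual scatter; since these two compounds differ in more than one place, only their values can be set side by side. Compound 4 `CC[C@@H]1C(=O)N(C)c2cnc(-n3ccc4cc(C(N)=O)ccc43)nc2N1C1CCCC1` has not yet been measured. It differs from compound 2 in one place: hydrogen in place of isopropyl on an amide-type nitrogen. Compound 1 carries the same carbamoyl group and was found "not active" (no number reported), which suggests this change weakens growth inhibition. The step is therefore expected to be a 3.6-fold higher number from compound 2 to compound 4 (0.56 log units; beyond the scatter), toward weaker inhibition. Compound 4 is estimated at 6000 nM, within 2000 nM to 20000 nM.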

Compound 4, concentration for 50% growth inhibition: 1830 nM
Compound 4: middle estimate off by 3.3-fold (0.52 log units), on the high side, outside the stated range (below it).
By their numbers in this assay, from the lowest: compounds 2 and 4 (each within the scatter of the next); then compound 3.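

In this assay, hydrogen in place of isopropyl on this amide-type nitrogen gives a 1.1-fold higher number from compound 2 to compound 4 (0.04 log units; within the scatter), so for this pair the isopropyl group can be removed with no measurable loss of growth inhibition. The isopropylcarbamoyl and the carbamoyl group cannot be told apart here. Nothing in the data shown gives a reason for this result. The compounds shown leave open whether this nitrogen also accepts a longer chain, such as n-butyl, or a chain ending in an amine.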